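A few compounds are considered here, and "the series" means these few. Any claim that something is new, unique, unknown or untested is made for them only; others in the source may bear on it.

Compound 1 `COc1ccc(C(=O)O)cc1OCCCCOc1ccc(C(=O)C(C)C)c(O)c1C` gives 116 nM in an assay on HEK293 cells for positive allosteric modulation of metabotropic glutamate receptor 2 (Rattus norvegicus), read by thallium flux, with a stated time of 2.5 min; on this read-out lower numbers stand for an effect already at smaller amounts and higher numbers for an effect only at larger amounts of compound. Compound 2 `COc1ccc(C(=O)O)cc1OCCCCOc1ccc(C(C)=O)c(O)c1C` differs from compound 1 by methyl in place of isopropyl on a carbonyl carbon; in this assay compound 2 gives 1090 nM, a step of a 9.4-fold higher number from compound 1 to compound 2 (0.97 log units; beyond the scatter). Compound 3 `Cc1c(OCCCCOc2ccc(F)c(C(=O)O)c2)ccc(C(=O)C(C)C)c1O` gives 171 nM in this assay; the difference between the core of compound 3 and the core of compound 1 is not broken down here. Compound 4 `CC(=O)c1ccc(OCCCCOc2ccc(F)c(C(=O)O)c2)c(C)c1O` is not yet measured and differs from compound 3 by methyl in place of isopropyl on a carbonyl carbon, the same change as that between compound 1 and compound 2, at a place described in the same terms. For compound 4 a step of an 8.8-fold higher number from compound 3 to compound 4 (0.94 log units; beyond the scatter) is expected, of similar size, because the same change gave a 9.4-fold higher number from compound 1 to compound 2 (0.97 log units; beyond the scatter). Compound 4 is therefore estimated at 1500 nM in this assay. For compound 4 the expected range runs from 600 nM to 4000 nM.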

Compound 4, half-maximal effective concentration: 259 nM
The estimate for compound 4 lay 5.8-fold (0.76 log units) above the measured number; measured number outside the range, below it.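

On the core of compound 3, the change from isopropyl to methyl on a carbonyl carbon gives a 1.5-fold higher number from compound 3 to compound 4 (0.18 log units; within the scatter) in this assay and so leaves no step beyond the scatter. The size of the step does not carry over between these two cores: the same change on two cores in this assay, a 9.4-fold higher number (0.97 log units; beyond the scatter) from compound 1 to compound 2 and a 1.5-fold higher number (0.18 log units; within the scatter) from compound 3 to compound 4, 6.2-fold (0.79 log units) apart, beyond the scatter of two such steps. The difference between the two cores is not broken down, so the two pairs do not show which part of it goes with the smaller step, and they give no rule for other cores in the series.

Open, on these data alone, is whether ethyl or cyclopropyl on the carbonyl carbon gives the large step or the small one on each core. Also open, as far as these compounds go, is how the change from isopropylcarbonyl to acetyl behaves on a further core, such as one with chlorine in place of fluorine.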